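Replacing 1,3-thiazol-2-yl on a sulfonamide nitrogen

This account rests on a few compounds, and the source may have more. Where it says the series, first, only, none or still open, it means among the compounds named here.

Measured in a functional assay on SK-OV-3 cells (Homo sapiens) for antiproliferative activity, read by sulforhodamine B assay, with a stated time of 72 h; a lower number here means a stronger inhibitor, a higher number a weaker inhibitor:
- compound 1 `Cc1cc(C)nc(NS(=O)(=O)c2ccc(Nc3nncc4ccccc34)cc2)n1`: 0.08 nM
- compound 2 `O=S(=O)(Nc1ncccn1)c1ccc(Nc2nncc3ccccc23)cc1`: 0.8 nM
- compound 3 `O=S(=O)(Nc1nccs1)c1ccc(Nc2nncc3ccccc23)cc1`: 7.7 nM

Compound 3 has the highest number of the three, and its steps to both others lie beyond the scatter. Compound 4 `O=S(=O)(Nc1ccccn1)c1ccc(Nc2nncc3ccccc23)cc1` keeps the shared core and differs in one group: pyridin-2-yl in place of 1,3-thiazol-2-yl on a sulfonamide nitrogen. Among the compounds with values here, three measured steps bear on this change, all at that same nitrogen. The pyrimidin-2-yl comparison gives a 9.6-fold higher number from compound 2 to compound 3 (0.98 log units; beyond the scatter), a modest step, while the 4,6-dimethylpyrimidin-2-yl comparison gives a 96-fold higher number from compound 1 to compound 3 (1.98 log units; beyond the scatter), a large one. Between those two groups lies a 10-fold higher number from compound 1 to compound 2 (1.00 log units; beyond the scatter). Pyridin-2-yl itself is unmeasured, so a modest move toward a lower number in this assay is expected, smaller than the pyrimidin-2-yl step. The expected step is a 2.6-fold lower number from compound 3 to compound 4 (0.41 log units; beyond the scatter). For compound 4 the estimated value is 3 nM, with an expected range of 0.5 nM to 18 nM.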

Compound 4, half-maximal inhibitory concentration: 0.9 nM
Compound 4: the middle estimate sits 3.3-fold (0.52 log units) above what was measured; measured number inside the range.
By their numbers in this assay, from the lowest: compound 1; then compounds 2 and 4 (each within the scatter of the next); then compound 3.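

In this assay, leaving 1,3-thiazol-2-yl for pyridin-2-yl on a sulfonamide nitrogen gives an 8.6-fold lower number from compound 3 to compound 4 (0.93 log units; beyond the scatter) and so shows that this group is not the only one to stand clear of 1,3-thiazol-2-yl. The pair pyrimidin-2-yl and pyridin-2-yl cannot be told apart here, with a 1.1-fold higher number from compound 2 to compound 4 (0.05 log units; within the scatter) as their step. Only the dimethylated group stands apart, with an 11-fold higher number from compound 1 to compound 4 (1.05 log units; beyond the scatter) as the step to pyridin-2-yl.

Still open, going by these compounds, is whether methyl groups on pyridin-2-yl would bring a similar step, and how a plain phenyl would compare at this nitrogen. Nothing shown here gives a measured reason for these differences.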